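The source may hold more compounds than are shown below. What is called first, only, known or untested is meant among the compounds shown, and "the series" means these compounds.

- Compound 1 `CCNCCNC(=O)c1cc(Cl)c(N)cc1OC`: > 30 mg/kg, which is a limit and not a number.
- Compound 2 `CCN(CCNC(=O)c1cc(Cl)c(N)cc1OC)Cc1ccc(Cl)cc1Cl`: 10 mg/kg.
- Compound 3 `CCCN(CCNC(=O)c1cc(Cl)c(N)cc1OC)Cc1ccc(Cl)cc1`: 3 mg/kg.
- Compound 4 `CCCCN(CCNC(=O)c1cc(Cl)c(N)cc1OC)Cc1ccc(Cl)cc1`: not yet measured.

All values come from a functional assay on the whole organism with Rattus norvegicus as the target; on this read-out lower numbers stand for an effect already at smaller amounts and higher numbers for an effect only at larger amounts of compound. Of the two actual numbers, compound 3 has the lower one, and its gap to compound 2 lies beyond the scatter. Compound 4 differs from compound 3 by turning propyl into butyl: methyl in place of hydrogen on a saturated chain carbon, three bonds along the chain from an amine nitrogen. Going by the values given here, the only single-place measured change is an at least 3.0-fold lower number from compound 1 to compound 2 (0.47 log units; beyond the scatter). It puts 2,4-dichlorobenzyl in place of hydrogen on an amine nitrogen, a much larger change than adding one methyl, so it bears only loosely here. Among the compounds with values here, no measured step lengthens a chain alone, so no change beyond the scatter is expected, and neither direction is favoured. The expected result is no change at the digits printed from compound 3 to compound 4 (within the scatter). For compound 4 the estimate is 3 mg/kg, with an expected range of 1 mg/kg to 10 mg/kg.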

Compound 4, dose for half-maximal effect: 20 mg/kg
Estimate against measurement, compound 4: 6.7-fold (0.82 log units) below; measured number above the stated range.
By their numbers in this assay, from the lowest: compound 3; then compounds 2 and 4 (each within the scatter of the next). At a limit, above all of these: compound 1.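

Turning propyl into butyl gives a 6.7-fold higher number from compound 3 to compound 4 (0.82 log units; beyond the scatter) in this assay. This shows that the chain on the amine nitrogen is not a neutral place: one added methyl, at the far end of that chain, means a clearly larger dose is needed for the same effect. Nothing measured here gives a cause for this step.

Open, on these data alone, is whether a pentyl chain would raise the number further. Also open, as far as these compounds go, is how a branched isobutyl group, or a hydroxyl at the chain end, would compare with propyl.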